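The source may report more compounds than this note shows. Statements on the series, on what has been measured and on what is new or still open speak of the compounds shown alone.

Going by the values given here, in a physicochemical assay for lipophilicity (a higher number here means a more lipophilic compound, a lower number a more polar compound), compound 1 `CC(C)(c1cc([C@@]23CCOC[C@@H]2C3)nc(-c2cccc(O)c2)n1)S(C)(=O)=O` gives 4.8 and stands highest of the three compounds measured so far. Compound 3 `CNCC(=O)Nc1ccc(-c2nc(C(C)(C)S(C)(=O)=O)cc([C@]34CCOC[C@H]3C4)n2)cc1` gives 4.3 and compound 2 `CCNC(=O)Nc1ccc(-c2nccc([C@]34CCOC[C@H]3C4)n2)cc1` gives 3.9 in the same measurement, and both lie lower than compound 1 by more than the scatter. Compound 4 `CC(C)(c1cc([C@]23CCOC[C@H]2C3)nc(-c2cccc(O)c2)n1)S(C)(=O)=O` has not yet been measured. The step to it is a purely stereochemical one: the two compounds have the same atoms and bonds and differ only in configuration as drawn: 2 of 2 stereo elements differ (all stereocentres are inverted: mirror images); a stereocentre at a saturated ring carbon is drawn S in compound 1 and R in compound 4; a stereocentre at a saturated ring carbon is drawn R in compound 1 and S in compound 4 and nothing else changes. Among the compounds with values here, no pair among the measured compounds shows such a change, so the expectation in this assay rests on the structural change alone and starts from compound 1 at 4.8 as its reference. No step beyond the scatter is expected, in either direction. The estimated no change at the digits printed from compound 1 to compound 4 (within the scatter) is accordingly expected to stay within the scatter of repeated measurements. For compound 4 the expected value is 4.8 with an estimated range from 4.5 to 5.1 around it.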

Compound 4, partition coefficient: 4.8
Beside the measured number, compound 4's estimate shows no gap at the digits printed; the measured number falls inside the stated range.
By their numbers in this assay, from the lowest: compound 2; then compound 3; then compounds 1 and 4 (each within the scatter of the next).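

In this assay, going by these compounds alone, the inversion of both stereocentres gives no change at the digits printed from compound 1 to compound 4 (within the scatter), and this is the first pair in the set whose two members differ in one place. Compounds 2 and 3 differ from compound 1 in more than one place, so their values could not show what any single change does, whereas this pair isolates one kind of change at the two saturated ring carbons. The comparison reads on configuration alone, and across this mirror-image pair the number does not separate, because of a single structural difference: the fact that compounds 1 and 4 differ only in the configuration as drawn

The compounds shown leave open what happens when only one of the two stereocentres is inverted, which would give a pair that is not a mirror image. They also leave open how the number responds to a change of substituent alone, such as replacing the hydroxyl group of compound 1 with a carboxylic acid or a nitrile.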